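The compounds below may be only part of what the source reports. "The series", "measured", "known", "first", "only" and "open" are said of these compounds alone.

In an ADME assay on HOS cells (Homo sapiens) for cytotoxicity, read by luminescence and ATP content, with a stated time of 48 h (a higher number here means that more compound is tolerated, a lower number that less compound is tolerated), compound 1 (`COc1ccc2c(N)c(C(=O)NCc3ccc(F)cc3F)c(=O)n(O)c2n1`) gives 2200 nM, compound 2 (`COC(=O)CNc1c(C(=O)NCc2ccc(F)cc2F)c(=O)n(O)c2nc(OC)ccc12`) gives 12000 nM and compound 3 (`Nc1c(C(=O)NCc2ccc(F)cc2F)c(=O)n(O)c2ncc(CCCC3CCCCC3)cc12`) gives 27400 nM, the highest of the three numbers. Compound 4 (`Nc1c(C(=O)NCc2ccc(F)cc2F)c(=O)n(O)c2ncc(CCC(=O)O)cc12`) has carboxy in place of cyclohexylmethyl on a saturated chain carbon, two bonds along the chain from an aromatic carbon. For the measured compounds named here, no measured step covers this change. Going by the values given here, the only guide is a 5.5-fold higher number from compound 1 to compound 2 (0.74 log units; beyond the scatter), made at a different place on the shared core, so it bears only weakly. On that thin basis, a modest rise is expected in this assay, with an estimated size of a 2.2-fold higher number from compound 3 to compound 4 (0.34 log units; beyond the scatter). For compound 4 the estimated value is 60000 nM, with an expected range of 15000 nM to 250000 nM.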

Compound 4, half-maximal cytotoxic concentration: > 250000 nM
Compound 4 was reported as a limit; the forecaster's own chance of this, stated with the estimate: 30%; middle value at least 4.1-fold (0.61 log units) away from the limit.
By their numbers in this assay, from the lowest: compound 1; then compound 2; then compound 3. At a limit, above all of these: compound 4.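

In this assay, carboxy in place of cyclohexylmethyl on a saturated chain carbon, two bonds along the chain from an aromatic carbon, gives an at least 9.1-fold higher number from compound 3 to compound 4 (0.96 log units; beyond the scatter). For the compounds shown here, the only earlier step, a 5.5-fold higher number from compound 1 to compound 2 (0.74 log units; beyond the scatter), lies at a different place on the shared core, so this is the first reading of a change at this position. Compound 4 stands at a limit of the assay, not at a number: the limit of > 250000 nM in this assay, at which 1 of the 4 values shown sits.

Still open, as far as these compounds go, is whether the step follows the loss of the cyclohexyl ring or the entry of carboxy. An amine or a primary amide at the end of the same chain would separate the two.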